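This account rests on a few compounds, and the source may have more. Where it says the series, first, only, none or still open, it means among the compounds named here.

Measured so far:
Compound 1 `C/C(=C\c1cc(-c2ccccc2)cs1)C(N)=O`: 12700 nM
Compound 2 `C/C(=C\c1cc(-c2ccc(C)cc2)cs1)C(N)=O`: a limit of the assay, > 50000 nM
Compound 3 `C/C(=C\c1cccc(-c2ccccc2)c1)C(N)=O`: 15700 nM

In a functional assay on HeLa cells (Homo sapiens) for cytotoxicity, read by CCK-8 assay, with a stated time of 24 h (a lower number here means a stronger inhibitor, a higher number a weaker inhibitor), compound 1 gives 12700 nM. Compound 2 reaches only a limit, > 50000 nM. The change methyl in place of hydrogen on an aromatic carbon therefore produces an at least 3.9-fold higher number from compound 1 to compound 2 (0.59 log units; beyond the scatter), a step whose true size is hidden by the limit of > 50000 nM in this assay, at which 1 of the 3 values shown sits. Compound 3 gives 15700 nM in this assay, a value within the scatter of compound 1; the difference between the two cores is not broken down here.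

Compound 4 `C/C(=C\c1cccc(-c2ccc(C)cc2)c1)C(N)=O` has not yet been measured. It differs from compound 3 by methyl in place of hydrogen on an aromatic carbon, the same change as that from compound 1 to compound 2, at a place described in identical words. Compound 4 is therefore expected to show a 2.9-fold higher number from compound 3 to compound 4 (0.46 log units; beyond the scatter), resting on the step of an at least 3.9-fold higher number from compound 1 to compound 2 (0.59 log units; beyond the scatter). The estimate for compound 4 is 45000 nM, between 18000 nM and 120000 nM, with a fair chance that only a limit is reported.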

Compound 4, half-maximal inhibitory concentration: 24800 nM
Beside the measured number, compound 4's estimate is 1.8-fold (0.26 log units) above it; the range from low to high includes it.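

In this assay, methyl in place of hydrogen on an aromatic carbon gives a 1.6-fold higher number from compound 3 to compound 4 (0.20 log units; within the scatter), so on the core of compound 3 the change does not move the number beyond the scatter. Set beside the step on the core of compound 1, the result reads: the same change on two cores in this assay, an at least 3.9-fold higher number (0.59 log units; beyond the scatter) from compound 1 to compound 2 and a 1.6-fold higher number (0.20 log units; within the scatter) from compound 3 to compound 4; the limit leaves it open whether they differ. The series therefore does not show that the change carries over from one core to the other with the same size, nor that its size differs, and compound 2 stands at a limit: the limit of > 50000 nM in this assay, at which 1 of the 4 values shown sits.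

The compounds shown leave open how an ethyl, a methoxy or a carboxylic acid at the same place would read on either core. They also leave open whether an amine at that place would behave alike on both cores.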